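A few compounds are considered here, and "the series" means these few. Any claim that something is new, unique, unknown or untested is made for them only; others in the source may bear on it.

In a functional assay on MIA PaCa-2 cells (Homo sapiens) for cytotoxicity, read by MTT assay, with a stated time of 72 h (a higher number here means a weaker inhibitor, a lower number a stronger inhibitor), compound 1 `COC1=CC(=O)c2c(COc3ccc([N+](=O)[O-])cc3)c(C)n(C)c2C1=O` gives 355 nM. Going by the values given here, the only other measured compound, compound 2 `COC1=CC(=O)c2c(COc3ccc([N+](=O)[O-])cc3F)c(C)n(C)c2C1=O`, gives 417 nM, so the two lie within the scatter of each other. Compound 3 `COC1=CC(=O)c2c(COc3ccc(C#N)cc3)c(C)n(C)c2C1=O` keeps the core of compound 1 but swaps one group: cyano in place of nitro on an aromatic carbon. Among the compounds with values here, the only measured step, a 1.2-fold higher number from compound 1 to compound 2 (0.07 log units; within the scatter), comes from fluoro in place of hydrogen on an aromatic carbon. Within the data shown here, that is a different change, so it bears on this swap only loosely, and no measured pair tests the loss of nitro directly. With so little evidence, no shift beyond the scatter is expected in this assay, though the uncertainty is wide. The estimated value for compound 3 is 400 nM, with an expected range from 150 nM to 1000 nM. The expected change is a 1.1-fold higher number from compound 1 to compound 3 (0.05 log units; within the scatter).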

Compound 3, half-maximal inhibitory concentration: 192 nM
Compound 3: the middle estimate sits 2.1-fold (0.32 log units) above what was measured; measured number inside the range.
By their numbers in this assay, from the lowest: compounds 3, 1 and 2 (each within the scatter of the next, the first and the last beyond it).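

Both earlier compounds carry nitro, so they could not show whether activity depends on that group. In this assay the swap to cyano on an aromatic carbon, para to a large group, gives a 1.8-fold lower number from compound 1 to compound 3 (0.27 log units; within the scatter) and so leaves compound 3 level with compound 1 within the usual scatter, even though nitro is gone. Within this pair, then, nitro is not needed at this position for cytotoxicity in these cells, and nothing measured here explains why the two groups read alike.

From the compounds shown here alone, it remains open whether this position would accept groups unlike these two, such as an amine, a carboxylic acid or a longer chain. It is also unknown whether fluoro on the same ring would read the same alongside cyano as it does alongside nitro.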